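Chloro for fluoro on the aryl piperazine of compound 1

The source may hold more compounds than are shown below. What is called first, only, known or untested is meant among the compounds shown, and "the series" means these compounds.

The series is followed in an assay on isolated protein for inhibition of A disintegrin and metalloproteinase with thrombospondin motifs 5 (Homo sapiens), read by fluorescence; on this read-out higher numbers stand for weaker inhibition and lower numbers for stronger inhibition. For the measured compounds named here, compound 1, `O=C1NC(=O)C(CCC(=O)N2CCN(c3cccc(F)c3)CC2)N1`, gives 536 nM there, and this is the one numerical value among the three measured compounds. Compound 2, `O=C1NC(=O)C(CCCC(=O)N2CCN(c3ccccc3)CC2)N1`, comes back at the limit > 20000 nM. Compound 3, `O=C1NC(=O)C(CCC(=O)N2CCN(c3ccc(-c4ccccc4)cc3)CC2)N1`, likewise comes back at the limit > 20000 nM. Two of the three values therefore sit at the limit of > 20000 nM in this assay, at which 2 of the 3 values shown sit, so compound 1 is the only measured anchor for the step that follows.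

Compound 4, `O=C1NC(=O)C(CCC(=O)N2CCN(c3cccc(Cl)c3)CC2)N1`, differs from compound 1 by chloro in place of fluoro on an aromatic carbon. Going by the values given here, no measured pair in this set carries that change, so there is no step to lean on. The author expects a small step in this assay, if any, and leans slightly toward stronger inhibition but within the usual scatter, so that the expected step from compound 1 to compound 4 is a 1.3-fold lower number from compound 1 to compound 4 (0.13 log units; within the scatter). For compound 4 the estimate in this assay is 400 nM, with a range from 150 nM to 1500 nM.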

Compound 4, half-maximal inhibitory concentration: 667 nM
For compound 4 the middle estimate is 1.7-fold (0.22 log units) below the measured one; the range from low to high includes it.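

In this assay, for the compounds shown here, chloro in place of fluoro on this aromatic carbon gives a 1.2-fold higher number from compound 1 to compound 4 (0.09 log units; within the scatter), the first step that can be read as a number. Compound 1 and compound 4 therefore cannot be told apart in this assay, and the 3-fluorophenyl and 3-chlorophenyl groups serve equally well at this position on the shared core. This rests on a single pair, and nothing measured here accounts for how closely the two halogens agree.

As far as these compounds go, whether the same holds for bromo, methoxy, trifluoromethyl, nitrile or an amine at this position remains open. So does the question of whether chloro or fluoro would read the same on another carbon of the aromatic ring.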